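A few compounds are considered here, and "the series" means these few. Any claim that something is new, unique, unknown or untested is made for them only; others in the source may bear on it.

Of the compounds shown here, three built on one shared core have been measured in a functional assay on PC-3 cells (Homo sapiens) for antiproliferative activity, read by MTT assay, with a stated time of 48 h; on this read-out lower numbers stand for stronger inhibition and higher numbers for weaker inhibition. Compound 1 `O=C(Nc1ccccc1)Nc1nnc(Sc2ncnc3scc(-c4ccncc4)c23)s1` gives 5700 nM. Compound 2 `O=C(Nc1cccc(Cl)c1)Nc1nnc(Sc2ncnc3scc(-c4ccncc4)c23)s1`, bearing chloro in place of hydrogen on an aromatic carbon, gives 8000 nM. Compound 3 `O=C(Nc1ccc(Cl)c(Cl)c1)Nc1nnc(Sc2ncnc3scc(-c4ccncc4)c23)s1` gives 3600 nM. On these numbers compound 2 stands highest: the step of a 1.4-fold higher number from compound 1 to compound 2 (0.15 log units; within the scatter) stays within the scatter, the step of a 2.2-fold lower number from compound 2 to compound 3 (0.35 log units; beyond the scatter) goes beyond it, and the step of a 1.6-fold lower number from compound 1 to compound 3 (0.20 log units; within the scatter) again lies within it.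

Compound 4 `COc1cccc(NC(=O)Nc2nnc(Sc3ncnc4scc(-c5ccncc5)c34)s2)c1` has not yet been measured. It differs from compound 2 in one place: methoxy in place of chloro on an aromatic carbon. Going by the values given here, no measured step swaps chloro for methoxy; the measured steps only put chloro where hydrogen stood, and the single step that bears on this very position, a 1.4-fold higher number from compound 1 to compound 2 (0.15 log units; within the scatter), is within the scatter, so taking that chloro away appears to change little. What methoxy at that place does is simply unknown from these data. In this assay the step from compound 2 is therefore expected to be small, a 1.3-fold lower number from compound 2 to compound 4 (0.12 log units; within the scatter), with no direction claimed beyond the scatter. Compound 4 is estimated at 6000 nM, with a range from 2500 nM to 14000 nM in this assay.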

Compound 4, half-maximal inhibitory concentration: 6800 nM
For compound 4 the middle estimate is 1.1-fold (0.05 log units) below the measured one, and the stated range covers the measured number.
By their numbers in this assay, from the lowest: compounds 3, 1, 4 and 2 (each within the scatter of the next, the first and the last beyond it).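

In this assay, methoxy at this place, on an aromatic carbon meta to a large group, can now be set beside both chloro and hydrogen: a 1.2-fold lower number from compound 2 to compound 4 (0.07 log units; within the scatter) and a 1.2-fold higher number from compound 1 to compound 4 (0.08 log units; within the scatter) are both within the scatter, so hydrogen, chloro and methoxy cannot be told apart here, even though methoxy carries a hydrogen-bond acceptor that chloro lacks. The larger exchange of 3,4-dichlorophenyl for 3-methoxyphenyl, a 1.9-fold higher number from compound 3 to compound 4 (0.28 log units; within the scatter), also stays within the scatter, whereas a 2.2-fold lower number from compound 2 to compound 3 (0.35 log units; beyond the scatter) goes beyond it, so the 3-chlorophenyl compound alone is separated from the 3,4-dichlorophenyl compound among these pairs. Nothing in the data given speaks to why these groups read alike.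

Going by these compounds, whether any group at this place can move the number beyond the scatter remains open, since a basic amine, a carboxylic acid or a longer chain such as butoxy has no value here. On these data alone, it is also open whether methoxy would read the same elsewhere on this aromatic ring, or together with a second group such as the chloro of compound 3.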